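The compounds below may be only part of what the source reports. "The series", "measured", "known", "first", "only" and "open" are said of these compounds alone.

Measured compounds:
compound 1, `COc1ccc(C2N=C(SCc3ccccc3Cl)NC(C)=C2C(=O)Nc2ccc(F)cc2)cc1OC`: 35.9%
compound 2, `COc1ccc(C2N=C(SCc3cccc(Cl)c3)NC(C)=C2C(=O)Nc2ccc(F)cc2)cc1OC`: 16.4%
compound 3, `CC1=C(C(=O)Nc2ccc(F)cc2)C(c2ccc([N+](=O)[O-])cc2)N=C(SCc2ccccc2Cl)N1`: 18.5%

All three were measured in a functional assay on the whole organism (artery, strain albino) with Rattus norvegicus as the target, with a stated time of 300 min, at a dose of 10 mg/kg by the oral route; a higher number here means more inhibition at the dose given (going by the name of the read-out), a lower number less inhibition. Compound 3 stands second of the three numbers: its value and that of compound 2 lie within the scatter of each other, so no order between them can be claimed, while compound 1 sits clearly higher, as the step of a number 17.4 percentage points lower from compound 1 to compound 3 (beyond the scatter) shows.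

Compound 4, `CC1=C(C(=O)Nc2ccc(F)cc2)C(c2ccc([N+](=O)[O-])cc2)N=C(SCc2ccc(F)cc2)N1`, has not yet been measured. It differs from compound 3 by 4-fluorophenyl in place of 2-chlorophenyl on a saturated chain carbon bound to a sulfur. Among the compounds with values here, of the measured steps, only one bears on this change: the move from compound 1 to compound 2 also alters the group on the saturated chain carbon bound to a sulfur, and there the number fell by a number 19.5 percentage points lower from compound 1 to compound 2 (beyond the scatter). The step of a number 17.4 percentage points lower from compound 1 to compound 3 (beyond the scatter) concerns the saturated ring carbon instead and says nothing about the benzyl group. Within the data shown here, no measured compound carries a 4-fluorobenzyl, so the expectation rests on that single step. Since changing the 2-chlorobenzyl in compound 1 lowered the number by a number 19.5 percentage points lower from compound 1 to compound 2 (beyond the scatter), a modest drop from compound 3 is expected, a number 9.5 percentage points lower from compound 3 to compound 4 (within the scatter), though a result within the scatter cannot be excluded. Compound 4 is therefore estimated at 9%, with a range from 0% to 24%.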

Compound 4, a percentage reported as inhibition, in the whole organism at one dose (the size of the read-out at that dose, not a potency): 30.3%
For compound 4 the middle estimate is 21.3 percentage points below the measured one; measured number above the stated range.
By their numbers in this assay, from the lowest: compounds 2 and 3 (each within the scatter of the next); then compounds 4 and 1 (each within the scatter of the next).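

Replacing 2-chlorophenyl with 4-fluorophenyl on a saturated chain carbon bound to a sulfur gave, in this assay, a number 11.8 percentage points higher from compound 3 to compound 4 (beyond the scatter) and so showed that a change at this position can raise the number as well as lower it. Within the data shown here, the only earlier step at this position, with 3-chlorophenyl entering, was a number 19.5 percentage points lower from compound 1 to compound 2 (beyond the scatter) in a compound carrying 3,4-dimethoxyphenyl on the saturated ring carbon, whereas the new step was read with 4-nitrophenyl there, so 2-chlorophenyl can no longer be taken as a group whose replacement generally lowers the number. Nothing at hand explains why the two replacements moved the number in opposite directions.

The halogen and its place on the ring change together in the new step, so the compounds shown cannot tell whether the rise follows the fluorine or the place it occupies. Also open, from the compounds shown here alone, are whether 4-fluorophenyl would give a similar rise with 3,4-dimethoxyphenyl on the saturated ring carbon, and how a 4-chlorobenzyl, an unsubstituted benzyl or a simple ethyl chain on the sulfur would compare.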